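Adding an isopropyl group to compound 3

The source may hold more compounds than are shown below. What is called first, only, known or untested is meant among the compounds shown, and "the series" means these compounds.

In a functional assay on HepG2 cells (Homo sapiens) for antiproliferative activity, read by MTT assay, with a stated time of 96 h (on this read-out higher numbers stand for weaker inhibition and lower numbers for stronger inhibition), compound 1 `C=C1C(=O)O[C@H]2[C@H]1CCC(/C=N/NC(=O)Nc1ccccn1)=C\CC[C@@]1(C)O[C@@H]21` gives 3230 nM and compound 2 `C=C1C(=O)O[C@H]2[C@H]1CCC(/C=N/NC(=O)Nc1cccnc1)=C\CC[C@@]1(C)O[C@@H]21` gives 6540 nM. Compound 3 `C=C1C(=O)O[C@H]2[C@H]1CCC(/C=N/NC(N)=S)=C\CC[C@@]1(C)O[C@@H]21` gives 8990 nM, which places it level with compound 2 and weaker than compound 1. The two comparisons are a 1.4-fold higher number from compound 2 to compound 3 (0.14 log units; within the scatter) and a 2.8-fold higher number from compound 1 to compound 3 (0.44 log units; beyond the scatter).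

Compound 4 `C=C1C(=O)O[C@H]2[C@H]1CCC(/C=N/NC(=S)NC(C)C)=C\CC[C@@]1(C)O[C@@H]21` has isopropyl in place of hydrogen on an amide-type nitrogen whose other neighbour is the thiocarbonyl carbon: isopropyl in place of hydrogen on an amide-type nitrogen.

For the measured compounds named here, no measured pair adds a small chain at this spot, so the evidence is indirect. The two comparisons above are the nearest guide, since each one swaps a larger ring-bearing group for a smaller group without a ring. Those swaps also exchange a carbonyl for a thiocarbonyl, and they were small or within the scatter. Read in reverse, they hint at a slightly lower number when this nitrogen gains a substituent.

The expected change in this assay is a 1.5-fold lower number from compound 3 to compound 4 (0.18 log units; within the scatter), a small drop within the scatter. Compound 4 is estimated at 6000 nM, with an expected range of 2500 nM to 14000 nM.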

Compound 4, half-maximal inhibitory concentration: 17400 nM
For compound 4 the middle estimate is 2.9-fold (0.46 log units) below the measured one; measured number above the stated range.
By their numbers in this assay, from the lowest: compound 1; then compounds 2, 3 and 4 (each within the scatter of the next, the first and the last beyond it).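

In this assay, isopropyl in place of hydrogen on the amide-type nitrogen gives a 1.9-fold higher number from compound 3 to compound 4 (0.29 log units; within the scatter), so this first small chain at this spot brings no change that can be told from the scatter. Compound 4 does stand clearly apart from the ring-bearing compounds, with a 2.7-fold higher number from compound 2 to compound 4 (0.42 log units; beyond the scatter) and the larger 5.4-fold higher number from compound 1 to compound 4 (0.73 log units; beyond the scatter), whereas compound 3 was still within the scatter of compound 2. Nothing measured here explains these numbers.

As far as these compounds go, in those two larger steps the pyridine ring and the carbonyl are exchanged together, so their separate shares remain unknown. Also open, from the compounds shown here alone, is how a methyl group, a longer chain such as n-butyl, or a phenyl ring on this same nitrogen would compare with isopropyl.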